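Nitrogen substituent change on the shared core

The compounds below may be only part of what the source reports. "The series", "measured", "known", "first", "only" and "open" are said of these compounds alone.

Measured compounds:
compound 1 `CCC(C)(C)/N=c1\c(O)c(O)\c1=N/Cc1ccc(C#N)cc1` — 1100 nM
compound 2 `CCC(C)(C)/N=c1\c(O)c(O)\c1=N/Cc1ccc(C#N)c(Cl)c1` — 260 nM

Both numbers come from a functional assay for inhibition, with Rattus norvegicus as the target; a lower number here means a stronger inhibitor, a higher number a weaker inhibitor. Compound 1 stands highest of the two; the nearest is compound 2, and the step is a 4.2-fold lower number from compound 1 to compound 2 (0.63 log units; beyond the scatter), a change of chloro in place of hydrogen on an aromatic carbon.

Compound 3 `CC[C@@H](C)/N=c1\c(O)c(O)\c1=N/Cc1ccc(C#N)cc1` is the next member. Relative to compound 1 the change is sec-butyl in place of 1,1-dimethylpropyl on a double-bonded nitrogen. For the measured compounds named here, the only measured step, a 4.2-fold lower number from compound 1 to compound 2 (0.63 log units; beyond the scatter), sits on the aromatic ring and not on the double-bonded nitrogen, so it gives no guide to what a smaller alkyl group on that nitrogen does. Going by the values given here, no measured step bears on this change. The expectation therefore rests on compound 1 alone: the step from compound 1 to compound 3 in this assay is expected to be small, a 1.4-fold higher number from compound 1 to compound 3 (0.13 log units; within the scatter), with a slight lean toward a higher number but not clearly beyond the scatter. Compound 3 is estimated at 1500 nM, in a range from 500 nM to 5000 nM.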

Compound 3, half-maximal inhibitory concentration: 4000 nM
Estimate against measurement, compound 3: 2.7-fold (0.43 log units) below, and the stated range covers the measured number.
By their numbers in this assay, from the lowest: compound 2; then compound 1; then compound 3.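

The double-bonded nitrogen is now shown to be a position that responds in this assay: sec-butyl in place of 1,1-dimethylpropyl gives a 3.6-fold higher number from compound 1 to compound 3 (0.56 log units; beyond the scatter). The direction is opposite to that of the aromatic chloro change, a 4.2-fold lower number from compound 1 to compound 2 (0.63 log units; beyond the scatter), so the series now holds one step towards a lower number and one towards a higher number, at two different places on the shared core. The change takes the group from 5 heavy atoms to 4 and brings in a defined stereocentre, but nothing available explains the step or separates these two differences.

Still open, as far as these compounds go, is whether the step follows the carbon count or the stereocentre, a question that the opposite sec-butyl stereoisomer or an unbranched n-butyl chain on the same nitrogen would address. Also open, from the compounds shown here alone, is how a larger group there, such as cyclohexyl or 1,1-dimethylbutyl, would read, and whether chloro on the aromatic carbon gives a comparable step when the nitrogen carries sec-butyl.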